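This account rests on a few compounds, and the source may have more. Where it says the series, first, only, none or still open, it means among the compounds named here.

Working notes on the series. The shared core is a lactam-bearing amide fragment carrying a diketone-like chain that ends in an aromatic ring; the chain length and the terminal group vary.

Compound 2 `O=C(CCCCCCCCCCc1ccccc1)CC(=O)N[C@H]1CCOC1=O` is measured in a functional assay on PC-3 cells (Homo sapiens) for cytotoxicity, read by sulforhodamine B assay, with a stated time of 5 days (a higher number here means a weaker inhibitor, a lower number a stronger inhibitor), where compound 2 gives 2000 nM. Compound 3 `O=C(CCCCCCCCCc1ccccc1)CC(=O)N[C@H]1CCOC1=O` carries the change phenyl in place of benzyl on a saturated chain carbon, nine bonds along the chain from a carbonyl carbon and in this assay compound 3 gives 4000 nM; the step is a 2.0-fold higher number from compound 2 to compound 3 (0.30 log units; within the scatter).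

Compound 1 `O=C(CCCc1ccccc1)CC(=O)N[C@H]1CCOC1=O` has a much shorter chain; how its core differs from that of compound 2 is not broken down here. In this assay compound 1 gives > 100000 nM, which is a limit of the assay and not a number, as shown by the limit of > 100000 nM in this assay, at which 1 of the 3 values shown sits.

Compound 4 `O=C(CCc1ccccc1)CC(=O)N[C@H]1CCOC1=O` is not yet measured. It differs from compound 1 by phenyl in place of benzyl on a saturated chain carbon, two bonds along the chain from a carbonyl carbon. This is the same kind of change as that from compound 2 to compound 3, but not the same: there the place is nine bonds along the chain from a carbonyl carbon, here two bonds along the chain from a carbonyl carbon.

For compound 4 the expected step is a step that the limit leaves unreadable from compound 1 to compound 4, resting on the step of a 2.0-fold higher number from compound 2 to compound 3 (0.30 log units; within the scatter), which pointed toward a higher number, and on the fact that compound 1 already stands at a limit. Compound 4 is therefore expected to give about 200000 nM, most likely again reported only as a limit, with a range from 100000 nM to 1000000 nM.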

Compound 4, half-maximal inhibitory concentration: > 100000 nM
Compound 4: only a limit was reported; the forecaster's own chance of this, stated with the estimate: 90%; the middle value does not contradict the limit.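

In this assay compound 4 gives > 100000 nM, which is a limit of the assay and not a number. No step from compound 1 to compound 4 can be read, because both compounds stand at this limit: the limit of > 100000 nM in this assay, at which 2 of the 4 values shown sit.

The compounds shown leave open what phenyl in place of benzyl does at this place, and at what chain length, going from compound 1 to compound 2, a readable value first appears.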